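The source may hold more compounds than are shown below. What is called first, only, known or untested is meant among the compounds shown, and "the series" means these compounds.

Measured compounds and their values in an assay on isolated protein with Bile acid receptor (Homo sapiens) as the target; on this read-out lower numbers stand for an effect already at smaller amounts and higher numbers for an effect only at larger amounts of compound:
Compound 1 `COC(=O)/C=C/c1cccc(N(Cc2ccc(/C=C/c3ccc(F)cc3)cc2)C(=O)NC(C)C)c1` gives 348 nM.
Compound 2 `COC(=O)/C=C/c1cccc(N(Cc2ccc(-c3cccc(OC)c3)cc2)C(=O)NC(C)C)c1` gives 1370 nM.
Compound 3 `COC(=O)/C=C/c1cccc(N(Cc2ccc(-c3ccc(C)cc3)cc2)C(=O)NC(C)C)c1` gives 449 nM.

Compound 3 sits together with compound 1, since a 1.3-fold higher number from compound 1 to compound 3 (0.11 log units; within the scatter) lies within the scatter, whereas compound 2 stands apart with a higher number, as a 3.1-fold lower number from compound 2 to compound 3 (0.48 log units; beyond the scatter) shows. All three share the same core and differ only in the group on the outer aromatic ring.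

Compound 4 `COC(=O)/C=C/c1cccc(N(Cc2ccc(-c3ccc(N(C)C)cc3)cc2)C(=O)NC(C)C)c1` keeps that arrangement and changes compound 3 in one place: dimethylamino in place of methyl on an aromatic carbon. For the measured compounds named here, no measured pair makes this exact change. Going by the values given here, the steps that bear on it are the other swaps on the same outer ring, a 3.1-fold lower number from compound 2 to compound 3 (0.48 log units; beyond the scatter) and a 1.3-fold higher number from compound 1 to compound 3 (0.11 log units; within the scatter), one modest and one within the scatter. From these, the expected step of a 1.3-fold higher number from compound 3 to compound 4 (0.13 log units; within the scatter) in this assay is small, at most a modest shift, with a slightly higher number somewhat more likely than a lower one. For compound 4 the estimated value in this assay is 600 nM, expected to lie between 200 nM and 2000 nM.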

Compound 4, half-maximal effective concentration: 162 nM
The estimate for compound 4 lay 3.7-fold (0.57 log units) above the measured number; the measured number lies below the stated range.
By their numbers in this assay, from the lowest: compound 4; then compounds 1 and 3 (each within the scatter of the next); then compound 2.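

In this assay, for the compounds shown here, the place on the outer ring proves more responsive than the earlier compounds suggested: dimethylamino in place of methyl gives a 2.8-fold lower number from compound 3 to compound 4 (0.44 log units; beyond the scatter), a step beyond the scatter for a swap of one small group on that ring. Compound 4 also separates from the other two biaryl-free comparison points, with a 2.1-fold lower number from compound 1 to compound 4 (0.33 log units; beyond the scatter) and an 8.5-fold lower number from compound 2 to compound 4 (0.93 log units; beyond the scatter), so it has the lowest number of the four, and each of its steps lies beyond the scatter. No measurement here explains why this change lowers the number.

On these data alone, it remains open whether the nitrogen or the extra carbons matter more at this place. A plain amine, a diethylamino group or a carboxylic acid in the same spot would help separate these possibilities.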